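Swapping methyl for chloro on the benzyl arm of compound 1

The compounds below may be only part of what the source reports. "The series", "measured", "known", "first", "only" and "open" are said of these compounds alone.

Measured compounds:
- compound 1, `Cc1ccc(Cn2cc(COc3ccc4c(=O)ccoc4c3)nn2)cc1`: 50700 nM
- compound 2, `N#Cc1ccc(Cn2cc(COc3ccc4c(=O)ccoc4c3)nn2)cc1`: > 100000 nM
- compound 3, `O=c1ccoc2cc(OCc3cn(Cc4cccc(F)c4)nn3)ccc12`: > 100000 nM

For the measured compounds named here, in a functional assay on A549 cells (Homo sapiens) for cytotoxicity, read by MTT assay, with a stated time of 48 h (on this read-out lower numbers stand for stronger inhibition and higher numbers for weaker inhibition), compound 1 gives 50700 nM, the only actual number among the three. The value of compound 2 is a limit of the assay, not a number. The value of compound 3 is likewise a limit. Both limits sit at the limit of > 100000 nM in this assay, at which 2 of the 3 values shown sit.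

Compound 4, `O=c1ccoc2cc(OCc3cn(Cc4ccc(Cl)cc4)nn3)ccc12`, differs from compound 1 by chloro in place of methyl on an aromatic carbon. Two measured steps start from compound 1: an at least 1.9-fold higher number from compound 1 to compound 2 (0.29 log units; that floor lies within the scatter) and an at least 1.9-fold higher number from compound 1 to compound 3 (0.29 log units; that floor lies within the scatter). On these data alone, both point the same way, towards a weaker result, but each only sets a floor that lies within the scatter, so the true size of either step is unknown. For a change of chloro in place of methyl on an aromatic carbon, a step of a 1.4-fold higher number from compound 1 to compound 4 (0.14 log units; within the scatter) is expected, within or at the edge of the scatter, with a fair chance that only a limit is reported. Compound 4 is therefore estimated at 70000 nM, in the range from 30000 nM to 200000 nM.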

Compound 4, half-maximal inhibitory concentration: > 100000 nM
Compound 4 was reported as a limit; the forecaster's own chance of this, stated with the estimate: 45%; middle value at least 1.4-fold (0.15 log units) away from the limit.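

In this assay compound 4 gives > 100000 nM, which is a limit of the assay and not a number. Chloro in place of methyl on this aromatic carbon gives an at least 1.9-fold higher number from compound 1 to compound 4 (0.29 log units; that floor lies within the scatter), so the step sets only a floor, and a second replacement at this position, after the nitrile of compound 2, also yields no actual number. The steps among compounds 2, 3 and 4 cannot be read, and methyl remains the only group at this position with a measured number: the limit of > 100000 nM in this assay, at which 3 of the 4 values shown sit.

On these data alone, the true size of the step from methyl to chloro stays unknown, as the floor does not separate the two compounds beyond the usual scatter. As far as these compounds go, whether a methoxy group, an amine or a longer chain at this position would give a lower number than compound 1 also remains open.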